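Lengthening the alkoxy chain on the oxime carbamate

The source may hold more compounds than are shown below. What is called first, only, known or untested is meant among the compounds shown, and "the series" means these compounds.

In an assay on H4 cells for inhibition of Fatty-acid amide hydrolase 1 (Homo sapiens) (a lower number here means a stronger inhibitor, a higher number a weaker inhibitor), compound 1 `CCCCOc1ccc(CNC(=O)Oc2ccc(F)cc2)cc1` gives 4.6 nM, whereas compound 2 `CCOc1ccc(NC(=O)O/N=C/c2ccccc2)cc1` gives 81 nM. For the measured compounds named here, of the two numbers measured so far, compound 2 stands highest, and compound 1 stands well apart from it, beyond the scatter; the two structures differ in more than one place, so the pair shows only where each lies and not the weight of any single change. Compound 3 `CCCCCCCOc1ccc(NC(=O)O/N=C/c2ccccc2)cc1` keeps the whole of compound 2 and carries one difference: pentyl in place of hydrogen on a saturated chain carbon, two bonds along the chain from an oxygen on an aromatic ring. Going by the values given here, no measured pair isolates this chain extension. Compound 3 is nevertheless expected to move toward a lower number in this assay, by a step of a 5.4-fold lower number from compound 2 to compound 3 (0.73 log units; beyond the scatter), because compound 1 gives 4.6 nM and also bears a longer alkoxy chain than compound 2. Compound 3 is estimated at 15 nM, within a range from 3 nM to 80 nM.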

Compound 3, half-maximal inhibitory concentration: 8.6 nM
For compound 3 the middle estimate is 1.7-fold (0.24 log units) above the measured one; the range from low to high includes it.
By their numbers in this assay, from the lowest: compounds 1 and 3 (each within the scatter of the next); then compound 2.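

Replacing ethoxy with heptyloxy gives a 9.4-fold lower number from compound 2 to compound 3 (0.97 log units; beyond the scatter) in this assay, so pentyl in place of hydrogen at this saturated chain carbon lowers the number on the shared core. For the compounds shown here, the only earlier pair differed in more than one place and could not weigh a single change, whereas this pair isolates the chain extension and gives it a size beyond the scatter. No measurement shown accounts for this shift.

A single step between two chain lengths does not show whether the number falls steadily through the intermediate chains, such as butoxy or pentyloxy, or whether it continues to fall with a longer chain such as decyloxy. From the compounds shown here alone, it also remains open how the number would respond to a chain ending in an amine or a carboxylic acid at the same place.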